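A few compounds are considered here, and "the series" means these few. Any claim that something is new, unique, unknown or untested is made for them only; others in the source may bear on it.

Of the compounds shown here, two on the shared core have numbers so far in a functional assay on T98G cells (Homo sapiens) for inhibition, read by MTT assay, with a stated time of 72 h; a higher number here means a weaker inhibitor, a lower number a stronger inhibitor. Compound 1 (`C/C1=C\CC[C@@]2(C)O[C@@H]2[C@H]2OC(=O)[C@@H](CN3CCCC3)[C@@H]2C[C@@H]1O`) gives 15000 nM and compound 2 (`C/C1=C\CC[C@@]2(C)O[C@@H]2[C@H]2OC(=O)[C@@H](CN3CCCCC3)[C@@H]2C[C@@H]1O`) gives 17000 nM, and these two values lie within the scatter of each other. The next compound is compound 3 (`C/C1=C\CC[C@@]2(C)O[C@@H]2[C@H]2OC(=O)[C@@H](CN3CCN(C)CC3)[C@@H]2C[C@@H]1O`), which carries 4-methylpiperazin-1-yl in place of piperidin-1-yl on a saturated chain carbon bound to a saturated ring carbon. Among the compounds with values here, one measured step bears on this change, at the same place: a 1.1-fold higher number from compound 1 to compound 2 (0.05 log units; within the scatter). Within the data shown here, no measured compound yet carries 4-methylpiperazin-1-yl, so that step is only a loose guide. A step no larger than the scatter is therefore expected in this assay, with no direction favoured. For compound 3 the expected step is a 1.1-fold lower number from compound 2 to compound 3 (0.03 log units; within the scatter). The estimate for compound 3 is 16000 nM, with an expected range of 8000 nM to 32000 nM.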

Compound 3, half-maximal inhibitory concentration: 23000 nM
Beside the measured number, compound 3's estimate is 1.4-fold (0.16 log units) below it; measured number inside the range.
By their numbers in this assay, from the lowest: compounds 1, 2 and 3 (each within the scatter of the next).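

In this assay, 4-methylpiperazin-1-yl in place of piperidin-1-yl on a saturated chain carbon bound to a saturated ring carbon gives a 1.4-fold higher number from compound 2 to compound 3 (0.13 log units; within the scatter), and 4-methylpiperazin-1-yl in place of pyrrolidin-1-yl gives a 1.5-fold higher number from compound 1 to compound 3 (0.19 log units; within the scatter). Within the data shown here, the earlier pair covered only two rings with 1 hetero atom, whereas these steps show that a six-membered ring with 2 hetero atoms also stays within the scatter at this place. No measured evidence bears on why these three groups read alike.

All three compounds carry a nitrogen ring at this place, so the shown data leave open how an open-chain dimethylamino group, a morpholin-4-yl ring or a carboxylic acid would read. Going by these compounds, whether any group here can move the number beyond the scatter also remains open.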